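The compounds below may be only part of what the source reports. "The series", "measured", "known", "first", "only" and "open" are said of these compounds alone.

Working notes on the series. Going by the values given here, compound 3 `C#CCN(C)CCCOc1ccc2ccc(=O)oc2c1` gives 36900 nM in an ADME assay on isolated protein for inhibition of Amine oxidase [flavin-containing] A (Homo sapiens), read by fluorescence and Amplex Red, with stated times of 15 min and 20 min (a higher number here means a weaker inhibitor, a lower number a stronger inhibitor), the lowest of the three numbers measured so far. Compound 1 `C#CCN(CCCOc1ccc2ccc(=O)oc2c1)Cc1ccc(OC)cc1` gives 60000 nM, and compound 2 `C#CCN(CCCOc1ccc2ccc(=O)oc2c1)Cc1ccc(C)cc1` gives 116000 nM. Between the two compounds that carry a substituted phenyl on the chain carbon, a 1.9-fold higher number from compound 1 to compound 2 (0.29 log units; within the scatter).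

Compound 4 `C#CCN(CCCOc1ccc2ccc(=O)oc2c1)Cc1ccc(F)c(F)c1` carries 3,4-difluorophenyl in place of hydrogen on a saturated chain carbon bound to an amine nitrogen. Among the compounds with values here, the steps that bear on this change run in the opposite direction: taking the 4-methoxyphenyl off gave a 1.6-fold lower number from compound 1 to compound 3 (0.21 log units; within the scatter), and taking the 4-methylphenyl off gave a 3.1-fold lower number from compound 2 to compound 3 (0.50 log units; beyond the scatter). Putting a substituted phenyl onto that carbon has thus raised the number in this assay by a small to modest amount in both known cases. Within the data shown here, no measured step shows how the 3,4-difluoro pattern compares with methyl or methoxy, so the two known steps are taken as the guide. The expected step is therefore a modest rise in the number, estimated as a 2.0-fold higher number from compound 3 to compound 4 (0.31 log units; beyond the scatter). Compound 4 is thus estimated at 75000 nM, with a range from 30000 nM to 180000 nM.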

Compound 4, half-maximal inhibitory concentration: 49200 nM
For compound 4 the middle estimate is 1.5-fold (0.18 log units) above the measured one; the range from low to high includes it.
By their numbers in this assay, from the lowest: compounds 3, 4, 1 and 2 (each within the scatter of the next, the first and the last beyond it).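

In this assay, 3,4-difluorophenyl in place of hydrogen on a saturated chain carbon bound to an amine nitrogen gives a small step (a 1.3-fold higher number from compound 3 to compound 4 (0.12 log units; within the scatter)), so a substituted phenyl at this position need not move the number beyond the scatter. Exchanging the ring substituents gives two different outcomes: replacing 4-methoxyphenyl gives a 1.2-fold lower number from compound 1 to compound 4 (0.09 log units; within the scatter), whereas replacing 4-methylphenyl gives a 2.4-fold lower number from compound 2 to compound 4 (0.37 log units; beyond the scatter), so the ring pattern shows a difference here only against compound 2. No evidence at hand bears on this result.

The compounds shown leave open what an unsubstituted benzyl, a pyridylmethyl or a longer chain between the amine nitrogen and the ring would give. They also leave open whether any group at this position gives a number clearly lower than that of compound 3.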